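Swapping the aryl group on the five-membered ring

This account rests on a few compounds, and the source may have more. Where it says the series, first, only, none or still open, it means among the compounds named here.

Two compounds with the shared core have numbers in a functional assay on mitochondria from heart for inhibition of peroxisomal acyl-coenzyme A oxidase 1 (Rattus norvegicus); a lower number here means a stronger inhibitor, a higher number a weaker inhibitor. Compound 1 `Cc1nc2cc(OC[C@H](O)CN3CCN(Cc4noc(-c5ccc(C(C)C)cc5)n4)CC3)ccc2s1` gives 950 nM in this assay, the lowest of the two. Compound 2 `Cc1nc2cc(OC[C@H](O)CN3CCN(Cc4coc(-c5ccc(C(F)(F)F)cc5)n4)CC3)ccc2s1` gives 11000 nM, a gap beyond the scatter. Compound 3 `Cc1nc2cc(OC[C@H](O)CN3CCN(Cc4noc(-c5cccc(Cl)c5)n4)CC3)ccc2s1` differs from compound 1 by 3-chlorophenyl in place of 4-isopropylphenyl on an aromatic carbon. For the measured compounds named here, no measured pair isolates this change, so the step is judged from compound 1 alone. Compound 3 is expected to be a weaker inhibitor, with a step of a 3.2-fold higher number from compound 1 to compound 3 (0.50 log units; beyond the scatter) in this assay, and its estimate is 3000 nM, between 1000 nM and 10000 nM.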

Compound 3, half-maximal inhibitory concentration: 4120 nM
For compound 3 the middle estimate is 1.4-fold (0.14 log units) below the measured one; the measured number falls inside the stated range.
By their numbers in this assay, from the lowest: compound 1; then compound 3; then compound 2.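

In this assay, 3-chlorophenyl in place of 4-isopropylphenyl on this aromatic carbon gives a 4.3-fold higher number from compound 1 to compound 3 (0.64 log units; beyond the scatter), so the aryl group at this position alters the number on the shared core. The earlier pair could not show this, as compound 1 and compound 2 differ in more than one place. Nothing available gives a reason for this step.

Going by these compounds, this change swaps both the substituent and where it sits on the phenyl ring, so the contribution of each remains open. On these data alone, how a phenyl ring bearing an amine or a carboxylic acid would behave here also remains open.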